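Pyridin-3-yl for 2-chlorophenyl on the methylene of the core

A few compounds are considered here, and "the series" means these few. Any claim that something is new, unique, unknown or untested is made for them only; others in the source may bear on it.

Compound 1 `Clc1ccccc1Cn1ccc2nc(-c3ccccc3)nc-2c1` has been run in an ADME assay on MDBK cells (Bos taurus) for cytotoxicity; a lower number here means that less compound is tolerated, a higher number that more compound is tolerated. In this assay compound 1 gives > 100000 nM, which is a limit of the assay and not a number. Compound 1 therefore stands at the limit of > 100000 nM in this assay, at which 1 of the 2 values shown sits. Compound 2 `c1ccc(-c2nc3ccn(Cc4cccc5ccccc45)cc-3n2)cc1` shares the same core and in this assay compound 2 gives 61000 nM. Among the compounds with values here, the two values together show only that neither compound is markedly toxic to these cells.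

Compound 3 `c1ccc(-c2nc3ccn(Cc4cccnc4)cc-3n2)cc1` is not yet measured. It differs from compound 1 by pyridin-3-yl in place of 2-chlorophenyl on a saturated chain carbon bound to an aromatic nitrogen. Within the data shown here, no pair of measured compounds differs in one place, so no comparable step is available. The step from compound 1 to compound 3 in this assay is expected to be small, a number no higher from compound 1 to compound 3 (the limit leaves the size open), and to stay within the usual scatter in either direction. Compound 3 is expected to give 100000 nM, with a range of 40000 nM to 250000 nM, and the result may again be reported only as a limit.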

Compound 3, half-maximal cytotoxic concentration: > 100000 nM
Compound 3: only a limit was reported (the forecaster's own chance of this, stated with the estimate: 55%); the middle value lies on the limit itself.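

No step can be read from compound 1 to compound 3, as both results in this assay are limits and not numbers: the limit of > 100000 nM in this assay, at which 2 of the 3 values shown sit.

The compounds shown leave open whether pyridin-3-yl in place of 2-chlorophenyl changes the tolerated concentration at all in this assay.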